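This account rests on a few compounds, and the source may have more. Where it says the series, first, only, none or still open, it means among the compounds named here.

Compound 1 `COc1cccc(OS(=O)(=O)c2ccc(N3CCN(C)C3=O)cc2)c1` carries a 3-methoxyphenyl on the oxygen that joins it to the sulfonyl sulfur. In a functional assay on MCF7 cells (Homo sapiens) for antiproliferative activity, read by sulforhodamine B assay, with a stated time of 48 h (a higher number here means a weaker inhibitor, a lower number a stronger inhibitor), compound 1 gives 3000 nM. Compound 2 `CN1CCN(c2ccc(S(=O)(=O)Oc3cccc(F)c3)cc2)C1=O` is the same molecule with one change, (fluoro in place of methoxy on an aromatic carbon). For compound 2 this assay reports only a limit, > 100000 nM, which sits at the limit of > 100000 nM in this assay, at which 1 of the 3 values shown sits. That single change therefore produced an at least 33-fold higher number from compound 1 to compound 2 (1.52 log units; beyond the scatter).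

Compound 3 `COc1ccc(OS(=O)(=O)c2ccc(N3CCN(C)C3=O)cc2)cc1` has the same atoms as compound 1 joined differently; the two cores differ by 4-methoxyphenyl in place of 3-methoxyphenyl on an oxygen. In this assay compound 3 gives 95000 nM, which is a 32-fold higher number from compound 1 to compound 3 (1.50 log units; beyond the scatter).

Compound 4 `CN1CCN(c2ccc(S(=O)(=O)Oc3ccc(F)cc3)cc2)C1=O` has not yet been measured. It differs from compound 3 by fluoro in place of methoxy on an aromatic carbon. For the measured compounds named here, this is the same kind of change as the one from compound 1 to compound 2, yet the place is not identical: in compound 2 the fluoro sits meta to a large group, whereas in compound 4 it sits para to a large group. The expected step is a 1.6-fold higher number from compound 3 to compound 4 (0.20 log units; within the scatter), resting on the earlier step of an at least 33-fold higher number from compound 1 to compound 2 (1.52 log units; beyond the scatter), in which the same replacement pushed the number past the limit. For compound 4 the estimate in this assay is 150000 nM, with a range expected from 50000 nM to 500000 nM, so a limit rather than a number is quite possible.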

Compound 4, half-maximal inhibitory concentration: > 100000 nM
Compound 4 was reported as a limit; the forecaster's own chance of this, stated with the estimate: 65%; the middle value does not contradict the limit.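

In this assay compound 4 is reported only as a limit, > 100000 nM. For the compounds shown here, the one step that can be stated for this change on the new core is an at least 1.0-fold higher number from compound 3 to compound 4 (0.02 log units; that floor lies within the scatter), so on neither core did fluoro in place of methoxy give a number the assay could read, and the data neither confirm nor rule out that the change carries over with the same size: the same change on two cores in this assay, an at least 33-fold higher number (1.52 log units; beyond the scatter) from compound 1 to compound 2 and an at least 1.0-fold higher number (0.02 log units; that floor lies within the scatter) from compound 3 to compound 4; the limit leaves it open whether they differ. Measured against the compound with the 3-methoxyphenyl group, the result is an at least 33-fold higher number from compound 1 to compound 4 (1.52 log units; beyond the scatter), whereas the step between compound 2 and compound 4 cannot be read, as both are limits: the limit of > 100000 nM in this assay, at which 2 of the 4 values shown sit.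

So the series shows that both fluoro compounds end up at the same limit, but it does not show how far beyond that limit either one lies, or whether the 3-fluorophenyl and 4-fluorophenyl groups differ at all. It also leaves open whether the value of compound 1 depends on methoxy itself, or whether a hydroxy, an ethoxy or an amine in the same place on the ring would keep a number well inside the range of the assay.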